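The compounds below may be only part of what the source reports. "The series", "measured", "known", "first", "only" and "open" are said of these compounds alone.

Measured in an ADME assay on MT4 cells (Homo sapiens) for cytotoxicity, read by MTT assay (on this read-out higher numbers stand for lower toxicity in this test and lower numbers for higher toxicity in this test), so far
Compound 1 `Cc1cc(C)cc(S(=O)(=O)c2c(C(=O)NCc3ccccc3N)[nH]c3ccc(Cl)cc23)c1` gives 46200 nM as a number
Compound 2 `Cc1cc(C)cc(S(=O)(=O)c2c(C(=O)NCc3cccc(O)c3)[nH]c3ccccc23)c1` gives > 5190 nM as a limit

Compound 2 has only the limit > 5190 nM and no number of its own. The change chloro in place of hydrogen on an aromatic carbon turns it into compound 3 `Cc1cc(C)cc(S(=O)(=O)c2c(C(=O)NCc3cccc(O)c3)[nH]c3ccc(Cl)cc23)c1` and puts chloro in place of hydrogen on an aromatic carbon. Among the compounds with values here, no measured step shows this change in this assay so the expectation rests on compound 1 at 46200 nM. The expectation points upward from the limit of compound 2. The expected step that the limit leaves unreadable from compound 2 to compound 3 is moderate and points to lower toxicity in this test. Compound 3 is estimated at 20000 nM with an expected range of 6000 nM to 80000 nM for now.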

Compound 3, half-maximal cytotoxic concentration: 27000 nM
Compound 3: the middle estimate sits 1.4-fold (0.13 log units) below what was measured; low and high end bracket the measured number.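

In this assay, within the data shown here, compound 3 gives the first number for the 3-hydroxyphenyl side group, which until now stood only as a limit. With chloro on the shared core, 3-hydroxyphenyl in place of 2-aminophenyl gives a 1.7-fold lower number from compound 1 to compound 3 (0.23 log units; within the scatter) and so does not separate the two side groups in this test. The step for chloro in place of hydrogen cannot be read, because compound 2 has only a limit: the limit of > 5190 nM in this assay, at which 1 of the 3 values shown sits.

Going by these compounds, whether chloro shifts the value on the 3-hydroxyphenyl compounds therefore stays open. Also open, on these data alone, is how fluoro, methoxy or an amine on that aromatic carbon would read.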